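Swapping Fluoro for Chloro on the Phenyl Ester

A few compounds are considered here, and "the series" means these few. Any claim that something is new, unique, unknown or untested is made for them only; others in the source may bear on it.

Of the compounds shown here, three built on one shared core have been tested in a functional assay on HT-1080 cells (Homo sapiens), read by transwell migration, with a stated time of 24 h, tested at 1 uM; on this read-out higher numbers stand for a weaker effect at the one concentration tested and lower numbers for a stronger effect. Compound 1 `CC(=O)OCc1ccc2oc(=O)c(C(=O)Oc3cccc(Cl)c3)cc2c1` gives 49.1%. Compound 2 `O=C(Oc1cccc(Cl)c1)c1cc2cc([N+](=O)[O-])ccc2oc1=O` gives 65.8%. Within the data shown here, the only step between two measured compounds is a number 16.7 percentage points higher from compound 1 to compound 2 (beyond the scatter). Compound 3 `CC(=O)NCc1ccc2oc(=O)c(C(=O)Oc3cccc(F)c3)cc2c1` gives 65.6%, the second highest of the three numbers as they stand, although its number and that of compound 2 lie within the scatter of each other, while compound 1 sits beyond the scatter below it.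

Compound 4 `CC(=O)NCc1ccc2oc(=O)c(C(=O)Oc3cccc(Cl)c3)cc2c1` has not yet been measured. It differs from compound 3 in one place: chloro in place of fluoro on an aromatic carbon. Among the measured compounds shown here, no measured step bears on this change; the one step that exists concerns acetoxymethyl and nitro, not the halogen on the phenoxy ring, so it offers no guide. Lacking any such guide, the step from compound 3 to compound 4 is expected to be a number 3.6 percentage points lower from compound 3 to compound 4 (within the scatter), nothing beyond the scatter. Compound 4 is therefore estimated at 62%, with a range from 45% to 80%.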

Compound 4, a percentage reported as activity, at one concentration (the size of the read-out at that concentration, not a potency): 36.6%
Estimate against measurement, compound 4: 25.4 percentage points above; the measured number lies below the stated range.
By their numbers in this assay, from the lowest: compound 4; then compound 1; then compounds 3 and 2 (each within the scatter of the next).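

In this assay, the halogen on the phenyl ester proves to matter: with the acetamidomethyl group held constant, 3-chlorophenyl in place of 3-fluorophenyl brings a number 29 percentage points lower from compound 3 to compound 4 (beyond the scatter) and so a stronger effect at the one concentration tested. With the 3-chlorophenyl ester held constant, the other side of the shared core also counts, with acetamidomethyl in place of nitro bringing a number 29.2 percentage points lower from compound 2 to compound 4 (beyond the scatter) and acetamido in place of acetoxy on the chain bringing a number 12.5 percentage points lower from compound 1 to compound 4 (beyond the scatter), which leaves compound 4 with the strongest effect of the four. Nothing measured here accounts for these steps.

On these data alone, whether fluoro and chloro would differ in the same way with the nitro or acetoxymethyl group on the core remains open. As far as these compounds go, how a bromo or methoxy group would read in place of the halogen also remains open.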